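The compounds below may be only part of what the source reports. "The series", "measured", "known", "first", "only" and "open" are said of these compounds alone.

In a functional assay on HCC1806 cells (Homo sapiens) for inhibition, read by sulforhodamine B assay, tested at 10 uM (on this read-out higher numbers stand for more inhibition at the one concentration tested (going by the name of the read-out) and lower numbers for less inhibition), three compounds have been measured so far:

Compound 1, `CC(=O)N1N=C(c2ccc(-n3ccnc3)cc2)CC1c1ccc(N(C)C)cc1`, gives -9.7%.
Compound 2, `CN(C)c1ccc(C2CC(c3ccc(-n4ccnc4)cc3)=NN2C(=O)CCCl)cc1`, gives -5.2%.
Compound 3, `CN(C)c1ccc(C2CC(c3ccc(-n4ccnc4)cc3)=NN2C(=O)c2ccc(F)cc2)cc1`, gives 7.1%.

Compound 3 stands highest of the three, and its distance from both others is beyond the scatter, while the gap between compound 1 and compound 2, a number 4.5 percentage points higher from compound 1 to compound 2 (within the scatter), is within it. Compound 4, `CN(C)c1ccc(C2CC(c3ccc(-n4ccnc4)cc3)=NN2S(C)(=O)=O)cc1`, is not yet measured. Its change from compound 3 is methylsulfonyl in place of (4-fluorophenyl)carbonyl on an amine nitrogen in a ring. The two steps that bear on this are a number 16.8 percentage points higher from compound 1 to compound 3 (beyond the scatter) and a number 12.3 percentage points higher from compound 2 to compound 3 (beyond the scatter), which also exchange the group on the carbonyl carbon: in each, moving from a group of few heavy atoms to the 4-fluorophenyl raised the number modestly. Methylsulfonyl is again a group of few heavy atoms, so for compound 4 a modest fall back toward the numbers of compound 1 and compound 2 is expected, a number 10.1 percentage points lower from compound 3 to compound 4 (beyond the scatter). The estimate for compound 4 in this assay is -3%, with a range from -18% to 12%.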

Compound 4, a percentage reported as inhibition, at one concentration (the size of the read-out at that concentration, not a potency): 11.3%
Compound 4: the middle estimate sits 14.3 percentage points below what was measured; measured number inside the range.
By their numbers in this assay, from the lowest: compounds 1 and 2 (each within the scatter of the next); then compounds 3 and 4 (each within the scatter of the next).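

In this assay the ring nitrogen of the shared core turns out not to need a ring-bearing group to reach the level of compound 3: methylsulfonyl, which has no ring, replaces (4-fluorophenyl)carbonyl with no change beyond the scatter (a number 4.2 percentage points higher from compound 3 to compound 4 (within the scatter)). The number of heavy atoms alone therefore does not order these compounds, since methylsulfonyl also stands apart from the ring-free carbonyl groups, both (2-chloroethyl)carbonyl (a number 16.5 percentage points higher from compound 2 to compound 4 (beyond the scatter)) and acetyl (a number 21 percentage points higher from compound 1 to compound 4 (beyond the scatter)). Nothing available explains why the sulfonyl group differs from these carbonyl groups.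

On these data alone, it remains open whether a larger sulfonyl group, such as ethylsulfonyl or phenylsulfonyl, would hold this level. The same question applies to a urea-type carbonyl carrying an amine on this nitrogen.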